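A Second Chloro Substitution, Estimated from the First

A few compounds are considered here, and "the series" means these few. Any claim that something is new, unique, unknown or untested is made for them only; others in the source may bear on it.

Of the compounds shown here, three of one small series have been measured in a functional assay on NCI-H322M cells (Homo sapiens) for cytotoxicity, read by sulforhodamine B assay, with a stated time of 48 h; on this read-out lower numbers stand for higher toxicity in this test and higher numbers for lower toxicity in this test. Compound 1 `ClCc1ccccc1Cn1cnc2c(Cl)nc(Cl)nc21` gives 5880 nM. Compound 2 `ClCc1ccccc1Cn1cnc2c(Cl)ncnc21` gives 43700 nM in this assay. Compound 3 `ClCc1cccc(Cn2cnc3c(Cl)ncnc32)c1` gives 6450 nM; its number and that of compound 1 lie within the scatter of each other, while its gap to compound 2 lies beyond it. Compound 4 `ClCc1cccc(Cn2cnc3c(Cl)nc(Cl)nc32)c1` has not yet been measured.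

Compound 1 differs from compound 2 by chloro in place of hydrogen on an aromatic carbon, and this change made a step of a 7.4-fold lower number from compound 2 to compound 1 (0.87 log units; beyond the scatter). Compound 4 stands to compound 3 in exactly the same way: chloro in place of hydrogen on an aromatic carbon, at a place described in the same words as before. How the core of compound 3 differs from the core of compound 2 is not broken down here, as the two share the same atoms joined differently.

Among the measured compounds shown here, since the single precedent is the step from compound 2 to compound 1, compound 4 is expected to show a step of a 6.5-fold lower number from compound 3 to compound 4 (0.81 log units; beyond the scatter) in this assay because a 7.4-fold lower number from compound 2 to compound 1 (0.87 log units; beyond the scatter) was the effect of the identical change. Compound 4 is thus estimated at 1000 nM in this assay. For the measured compounds named here, only one prior instance exists. The expected range for compound 4 is kept wide, from 300 nM to 3500 nM.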

Compound 4, concentration lethal to 50% of the cells: 15900 nM
Compound 4: the middle estimate sits 16-fold (1.20 log units) below what was measured; measured number outside the range, above it.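

In this assay, chloro in place of hydrogen on an aromatic carbon gave a 2.5-fold higher number from compound 3 to compound 4 (0.39 log units; beyond the scatter), so the change did not carry its earlier direction over to the core of compound 3. The two steps differ in direction as well as in size, and the gap between them is larger than scatter alone would account for: the same change on two cores in this assay, a 7.4-fold lower number (0.87 log units; beyond the scatter) from compound 2 to compound 1 and a 2.5-fold higher number (0.39 log units; beyond the scatter) from compound 3 to compound 4, 18-fold (1.26 log units) apart, beyond the scatter of two such steps This shows that, among these four compounds, the result of this change depends on the core that carries it, and that a step read on one of these cores gave no safe guide to the step on the other; it does not show what in the two cores, which share the same atoms joined differently, produces the split, nor whether either direction would recur on any further core.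

The compounds shown leave open whether an amine or a methoxy group at this same place, on the aromatic carbon between two ring nitrogen atoms, would also respond differently on the two cores. They also leave open whether the split would persist if the chloro at that place were replaced by a bromo group, or if the chloromethyl group were replaced by a hydroxymethyl group.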